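This account rests on a few compounds, and the source may have more. Where it says the series, first, only, none or still open, it means among the compounds named here.

Compound 3, `CC(C)(C)c1ccc(N2C(=O)C=CC2OCC(F)(F)F)cc1`, gives the lowest number of the three compounds measured in a functional assay on MDA-MB-231 cells (Homo sapiens) for inhibition (a lower number here means a stronger inhibitor, a higher number a weaker inhibitor), at 1860 nM. Compound 1, `CC(C)c1ccc(N2C(=O)C=CC2OCC(F)(F)F)cc1`, gives 6640 nM, and compound 2, `O=C1C=CC(OCC(F)(F)F)N1c1ccccc1`, gives 15300 nM. The step from compound 3 to compound 4, `O=C1C=CC(OCC(F)(F)F)N1c1ccc(Br)cc1`, is bromo in place of tert-butyl on an aromatic carbon. Among the compounds with values here, the steps that bear on it both touch the same aromatic carbon: an 8.2-fold lower number from compound 2 to compound 3 (0.92 log units; beyond the scatter) and a 3.6-fold lower number from compound 1 to compound 3 (0.55 log units; beyond the scatter), so a smaller group there has so far gone with a higher number. Bromo is smaller than tert-butyl but larger than hydrogen, so compound 4 is expected to land between compound 3 and compound 2, a modest rise of a 2.7-fold higher number from compound 3 to compound 4 (0.43 log units; beyond the scatter). The estimate for compound 4 is 5000 nM, within a range from 1500 nM to 16000 nM.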

Compound 4, half-maximal inhibitory concentration: 7570 nM
The estimate for compound 4 lay 1.5-fold (0.18 log units) below the measured number, within the range that was stated.
By their numbers in this assay, from the lowest: compound 3; then compounds 1 and 4 (each within the scatter of the next); then compound 2.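

Within the data shown here, replacing tert-butyl with bromo on this aromatic carbon gives a 4.1-fold higher number from compound 3 to compound 4 (0.61 log units; beyond the scatter) and leaves tert-butyl with the lowest number so far. Bromo still does better than hydrogen, with a 2.0-fold lower number from compound 2 to compound 4 (0.31 log units; beyond the scatter) as the step. Against isopropyl the step is a 1.1-fold higher number from compound 1 to compound 4 (0.06 log units; within the scatter) and so the two cannot be told apart, which shows that a single halogen atom here can give a number like that of a branched carbon group. From the compounds shown here alone, whether an amine, a methoxy group or a carboxylic acid at this position could approach compound 3 stays open. Nothing available explains these differences.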